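The source may hold more compounds than are shown below. What is called first, only, known or untested is meant among the compounds shown, and "the series" means these compounds.

Three compounds sharing one core were tested in an assay on membranes from CHO cells for displacement of a labelled ligand from adenosine receptor A1 (Homo sapiens), read by scintillation counting, with a stated time of 60 min, tested at 1 uM; a lower number here means less inhibition, a higher number more inhibition at the concentration tested (going by the name of the read-out). Compound 1 `CC1=C(C(N)=O)C(c2ccoc2)NC(=O)N1` gives 1%, compound 2 `CC1=C(C(N)=O)C(c2ccsc2)NC(=O)N1` gives 2%, and compound 3 `CCC(C)OC(=O)C1=C(C)NC(=O)NC1c1cccs1` gives 5%. The step of a number 1 percentage points higher from compound 1 to compound 2 (within the scatter) shows that thiophen-3-yl in place of furan-3-yl on a saturated ring carbon changes nothing beyond the scatter. Compound 2 stands second of the three numbers, with compound 1 nearest and compound 3 furthest, all within the scatter of one another. Compound 4 `CC1=C(C(=O)OC2CCCCC2)C(c2ccsc2)NC(=O)N1` differs from compound 2 by cyclohexyloxy in place of amino on a carbonyl carbon. Among the compounds with values here, no measured step bears on this change; compound 3 carries another group on its carbonyl carbon but differs elsewhere too, and it gives 5%. The step is therefore expected to be a number 1 percentage points higher from compound 2 to compound 4 (within the scatter), not beyond the scatter. Compound 4 is estimated at 3%, between -4% and 12%.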

Compound 4, a percentage reported as inhibition, at one concentration (the size of the read-out at that concentration, not a potency): 8%
For compound 4 the middle estimate is 5 percentage points below the measured one; measured number inside the range.
By their numbers in this assay, from the lowest: compounds 1, 2, 3 and 4 (each within the scatter of the next).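

In this assay, cyclohexyloxy in place of amino on a carbonyl carbon gives a number 6 percentage points higher from compound 2 to compound 4 (within the scatter). Within the data shown here, this is the first direct reading at this position: a group of 7 heavy atoms with a six-membered ring, replacing a single nitrogen, moves the number no further than the scatter at the concentration tested. Nothing measured here offers an explanation for this result. On these data alone, whether a carboxylic acid or a longer carbon chain on this carbonyl carbon would move the number beyond the scatter remains open. So does how cyclohexyloxy behaves with furan-3-yl on the saturated ring carbon.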